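The source may report more compounds than this note shows. Statements on the series, on what has been measured and on what is new or still open speak of the compounds shown alone.

Of the compounds shown here, two built on a shared core have been measured in a functional assay on COLO 205 cells (Homo sapiens) for inhibition, read by sulforhodamine B assay, with a stated time of 48 h; a higher number here means a weaker inhibitor of growth, a lower number a stronger inhibitor of growth. Compound 1 `COc1ccc(-c2cc(/C=C/C(=O)c3ccc(N)cc3)[nH]n2)cc1` gives 1850 nM in this assay. Compound 2 `COc1cc(-c2cc(/C=C/C(=O)c3ccc(N)cc3)[nH]n2)cc(OC)c1OC` gives 1740 nM in this assay. Compound 2 holds the lower of the two numbers, yet its gap to compound 1 lies within the usual scatter of repeated measurements, so the two cannot be told apart on growth inhibition. Compound 3 `COc1ccc(-c2cc(/C=C/C(=O)c3ccc(N)cc3)[nH]n2)cc1OC` has not yet been measured in this assay. It differs from compound 2 in one place: hydrogen in place of methoxy on an aromatic carbon. Going by the values given here, no step between measured compounds covers this change, so the expectation rests on what the two values show. Compound 1 gives 1850 nM and compound 2 gives 1740 nM, numbers within the scatter of each other although they differ in the number of methoxy groups on that ring. On that ground the step from compound 2 to compound 3 is expected to be a 1.0-fold higher number from compound 2 to compound 3 (0.01 log units; within the scatter), none beyond the scatter. Compound 3 is estimated at 1800 nM in this assay, with a range from 900 nM to 3600 nM.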

Compound 3, concentration for 50% growth inhibition: 1880 nM
Compound 3: middle estimate off by 1.0-fold (0.02 log units), on the low side; the range from low to high includes it.
By their numbers in this assay, from the lowest: compounds 2, 1 and 3 (each within the scatter of the next).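

Compounds 1 and 2 differ in more than one place, so their values could not show what a single methoxy group contributes; compound 3 supplies the first single-place comparisons. In this assay, hydrogen in place of methoxy on an aromatic carbon, ortho to a methoxy group and meta to a large group, gives a 1.1-fold higher number from compound 2 to compound 3 (0.03 log units; within the scatter), and methoxy in place of hydrogen on an aromatic carbon gives a 1.0-fold higher number from compound 1 to compound 3 (0.01 log units; within the scatter), so each of these two single changes on this ring stays within the scatter. No measurement shown here offers an explanation for this flat result.

The compounds shown all carry at least one methoxy group on this ring, so it remains open whether the ring with no methoxy group at all would stay within the scatter of these three. Going by these compounds, compound 2 gives 1740 nM, and it is also open whether a hydroxy group, a chlorine atom or a longer ethoxy chain at the position studied here would give a number beyond the scatter of that value.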